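The compounds below may be only part of what the source reports. "The series", "measured", "known", "first", "only" and "open" are said of these compounds alone.

Of the compounds shown here, two sharing one core have so far been tested in a functional assay on HeLa cells (Homo sapiens) for antiproliferative activity, with a stated time of 24 h; on this read-out higher numbers stand for weaker inhibition and lower numbers for stronger inhibition. Compound 1 `COc1ccccc1NC(=S)N1CCc2c(sc(NC(=O)c3ccccc3Cl)c2C(N)=O)C1` gives in this assay only a limit rather than a number, > 50000 nM. Compound 2 `NC(=O)c1c(NC(=O)c2ccccc2I)sc2c1CCN(C(=S)Nc1ccccc1Br)C2` likewise gives in this assay only a limit, > 50000 nM. Going by the values given here, compound 2 thus stands where the one other measured compound stands, both at the same limit (the limit of > 50000 nM in this assay, at which 2 of the 2 values shown sit), and no finished number exists for either of them. Compound 3 `COc1ccccc1NC(=S)N1CCc2c(sc(NC(=O)c3ccccc3I)c2C(N)=O)C1` has not yet been measured in this assay. It differs from compound 2 by methoxy in place of bromo on an aromatic carbon. Among the compounds with values here, with both measured values sitting at the limit, no step between measured compounds can be read. No change beyond the scatter is expected, and the step from compound 2 to compound 3 is estimated at a step that the limit leaves unreadable from compound 2 to compound 3. Compound 3 is expected to give about 80000 nM in this assay, with a range from 30000 nM to 300000 nM, most probably reported again as a limit.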

Compound 3, half-maximal inhibitory concentration: > 50000 nM
Compound 3: no number, only a limit; the forecaster's own chance of this, stated with the estimate: 85%; the middle value is on the limit's open side.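

Going by these compounds alone, compound 3 also gives only a limit in this assay, so no step from compound 1 or compound 2 to compound 3 can be read: the limit of > 50000 nM in this assay, at which 3 of the 3 values shown sit. The compounds shown leave open which change to the shared core, if any, would yield a finished number.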